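Removing One Fluorine From the Core of Compound 1

The source may hold more compounds than are shown below. What is called first, only, known or untested is meant among the compounds shown, and "the series" means these compounds.

Compound 1 `O=C(/C=C1\CCc2c(F)cc(F)cc21)NC1CC1`: 100%
Compound 2 `CCNC(=O)/C=C1\CCc2c(F)cc(F)cc21`: 67%

In a functional assay on the whole organism with Mus musculus as the target, at a dose of 100 mg/kg by the intraperitoneal route (on this read-out higher numbers stand for more inhibition at the one dose given (going by the name of the read-out) and lower numbers for less inhibition), compound 1 stands highest of the two numbers. Going by the values given here, the only measured step is a number 33 percentage points lower from compound 1 to compound 2 (beyond the scatter), brought about by ethyl in place of cyclopropyl on an amide-type nitrogen. Compound 3 `O=C(/C=C1\CCc2ccc(F)cc21)NC1CC1` keeps that cyclopropyl amide and differs from compound 1 elsewhere: hydrogen in place of fluoro on an aromatic carbon. Among the compounds with values here, no measured step touches the aromatic ring, so the one known step gives no direct guide to this change. With nothing to point either way, the expectation is a step of a number 10 percentage points lower from compound 1 to compound 3 (within the scatter) that stays within the scatter, leaning slightly downward because compound 1 already gives 100% and cannot rise further. Compound 3 is therefore estimated at 90%, within 65% to 100%.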

Compound 3, a percentage reported as inhibition, in the whole organism at one dose (the size of the read-out at that dose, not a potency): 100%
Compound 3: middle estimate off by 10 percentage points, on the low side; the measured number falls inside the stated range.
By their numbers in this assay, from the lowest: compound 2; then compounds 1 and 3 (each within the scatter of the next).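

In this assay, hydrogen can take the place of the fluoro group on the aromatic carbon ortho to a fused ring, with no change at the digits printed from compound 1 to compound 3 (within the scatter). Going by these compounds alone, this is the first sign that the aromatic part of the core of compound 1 can accept a change, as the earlier step concerned only the group on the amide nitrogen. Nothing at hand explains why this fluoro group can be lost without a change in the number.

Compound 1 and compound 3 both sit at the top of the percentage scale at the one dose given, so lower doses would be needed to tell them apart. The compounds shown also leave open what the remaining fluoro group contributes, and whether a chlorine or a methoxy group at this aromatic carbon would fare as well as hydrogen.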